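From compound 1 to its bromo analogue

A few compounds are considered here, and "the series" means these few. Any claim that something is new, unique, unknown or untested is made for them only; others in the source may bear on it.

Three compounds have been measured so far in an ADME assay on HaCaT cells (Homo sapiens) for inhibition, read by sulforhodamine B assay, with a stated time of 48 h (on this read-out higher numbers stand for weaker inhibition of growth and lower numbers for stronger inhibition of growth), as follows:
Compound 1 `S=C(N/N=C/c1cccs1)Nc1ccccc1` gives > 100000 nM as a limit
Compound 2 `S=C(N/N=C/c1cccs1)Nc1cccc2ccccc12` gives 82400 nM as a number
Compound 3 `C=CCNC(=S)N/N=C/c1cccs1` gives > 100000 nM as a limit

Compound 1 gives only a limit and stands at the limit of > 100000 nM in this assay, at which 2 of the 3 values shown sit. Compound 4 `S=C(N/N=C/c1cccs1)Nc1ccc(Br)cc1` differs from it in one place, with bromo in place of hydrogen on an aromatic carbon, para to a large group (bromo in place of hydrogen on an aromatic carbon). Among the compounds with values here, no measured step bears on this change. Within the data shown here, compound 2 gives 82400 nM and is the only number available, so a modest step toward lower numbers is expected. No readable step is expected if compound 4 stays at the limit. The expected change is (an at least 1.2-fold lower number from compound 1 to compound 4 (0.09 log units; that floor lies within the scatter)). In this assay compound 4 is estimated at 80000 nM within an expected range of (30000 nM to 100000 nM).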

Compound 4, concentration for 50% growth inhibition: 800 nM
Compound 4: the middle estimate sits 100-fold (2.00 log units) above what was measured; measured number below the stated range.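

In this assay, a single bromo in place of hydrogen on an aromatic carbon, para to a large group, gives an at least 120-fold lower number from compound 1 to compound 4 (2.09 log units; beyond the scatter). This one position on the ring can therefore carry a change that moves a compound off the limit to a readable number. The size of the step is only a floor, because compound 1 gives a limit and not a number: the limit of > 100000 nM in this assay, at which 2 of the 4 values shown sit.

Going by these compounds, whether a chloro group, a methoxy group or an amine at this place would do the same stays open. So does the effect of bromo elsewhere on this ring.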